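Series notes: the step from compound 3 to compound 4

The source may hold more compounds than are shown below. What is called first, only, known or untested is meant among the compounds shown, and "the series" means these compounds.

Measured so far:
compound 1 `Cc1ccc(-c2ccc3c(c2)C(=O)C(=O)N3)cc1` — 6000 nM
compound 2 `O=C1Nc2ccc(-c3ccc(C(F)(F)F)cc3)cc2C1=O` — 5430 nM
compound 3 `COc1ccc(-c2ccc3c(c2)C(=O)C(=O)N3Cc2ccc(Cl)cc2)cc1` — 250 nM

In a functional assay on HepG2 cells (Homo sapiens) for antiproliferative activity, read by MTT assay, with a stated time of 48 h (a higher number here means a weaker inhibitor, a lower number a stronger inhibitor), compound 1 gives 6000 nM and compound 2 gives 5430 nM. Among the compounds with values here, the one step between compounds that differ in a single place, a 1.1-fold lower number from compound 1 to compound 2 (0.04 log units; within the scatter), is within the scatter, so these two numbers are read as the same. Compound 3 gives 250 nM, the lowest number of the three; its gaps to compound 2 and to compound 1 are both beyond the scatter, so compound 3 is the strongest inhibitor among the measured compounds. Within the data shown here, compound 3 also carries a substituent on the ring nitrogen that neither compound 1 nor compound 2 has, and no measured pair isolates that substituent.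

Compound 4 `COc1ccc(-c2ccc3c(c2)C(=O)C(=O)N3Cc2ccc3ccccc3c2)cc1` differs from compound 3 in exactly that substituent: naphthalen-2-yl in place of 4-chlorophenyl on a saturated chain carbon bound to an amide-type nitrogen in a ring. Among the measured compounds shown here, no measured step bears on this change: the single step on record concerns a group on an aromatic carbon, not a group on the nitrogen-bound chain carbon. With nothing to draw on, the expectation is no step beyond the scatter, in either direction, no change at the digits printed from compound 3 to compound 4 (within the scatter). Compound 4 is therefore estimated at 250 nM, with a range from 90 nM to 700 nM in this assay.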

Compound 4, half-maximal inhibitory concentration: 380 nM
The estimate for compound 4 lay 1.5-fold (0.18 log units) below the measured number, and the stated range covers the measured number.
By their numbers in this assay, from the lowest: compounds 3 and 4 (each within the scatter of the next); then compounds 2 and 1 (each within the scatter of the next).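

In this assay, putting naphthalen-2-yl in place of 4-chlorophenyl on a saturated chain carbon bound to an amide-type nitrogen in a ring gives a 1.5-fold higher number from compound 3 to compound 4 (0.18 log units; within the scatter), and the two numbers are read as the same. Within the data shown here, this is the first single-place step on record at this position, where the only earlier step concerned a group on an aromatic carbon, and it shows that the position holds the read-out within the scatter on going from one six-membered aromatic ring of carbon only, with chlorine, to two such rings and no chlorine. Nothing on record gives a reason for this outcome.

All the same, both compounds in this pair carry an aromatic ring on the chain carbon, and the compounds shown do not tell how an amine, a carboxylic acid or a longer alkyl chain would read at this place. Among these compounds, no single-place step links the amide hydrogen of compound 1 or compound 2 to the substituted nitrogen of compound 3 or compound 4, and what the substituent on that nitrogen contributes as such remains unread.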